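Dimethylamino in Place of Piperidin-1-yl: Expected Inhibition

The compounds below may be only part of what the source reports. "The series", "measured", "known", "first", "only" and "open" are said of these compounds alone.

Compound 3 `N#C[C@@H]1CCCN1C(=O)[C@@H]1C[C@H](C(=O)N2CCCCC2)CN1` in an assay on the whole organism (plasma, strain Sprague-Dawley) for inhibition of Dipeptidyl peptidase 4 (Rattus norvegicus), with a stated time of 6 h, at a dose of 1 mg/kg by the oral route (on this read-out higher numbers stand for more inhibition at the one dose given (going by the name of the read-out) and lower numbers for less inhibition), gives 84%.
Compound 1 `CCC[C@@H]1CN[C@H](C(=O)N2CCC[C@H]2C#N)C1` in this assay gives 50%.
Compound 2 `C=CC[C@@H]1CN[C@H](C(=O)N2CCC[C@H]2C#N)C1` in this assay gives 38%.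

Compound 3 stands highest of the three numbers; its nearest neighbour, compound 1, lies lower by a step beyond the scatter, and compound 2 lies furthest below it. Compound 4 `CN(C)C(=O)[C@@H]1CN[C@H](C(=O)N2CCC[C@H]2C#N)C1` differs from compound 3 in one place: dimethylamino in place of piperidin-1-yl on a carbonyl carbon. For the measured compounds named here, the only step recorded between measured compounds, a number 12 percentage points lower from compound 1 to compound 2 (beyond the scatter), concerns the chain on a saturated ring carbon and not the group on the carbonyl carbon, so it does not bear directly on this change. Compounds 1 and 2, which carry a chain rather than a carbonyl-linked amine at that position, both sit well below compound 3, and compound 4 keeps the carbonyl and the amine. Going by the values given here, no measured step tells how exchanging one amine on that carbonyl for another plays out, so only a small downward shift is expected: a number 14 percentage points lower from compound 3 to compound 4 (beyond the scatter). Compound 4 is therefore estimated to give 70%, within a range from 45% to 90%.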

Compound 4, a percentage reported as inhibition, in the whole organism at one dose (the size of the read-out at that dose, not a potency): 76%
The estimate for compound 4 lay 6 percentage points below the measured number; low and high end bracket the measured number.
By their numbers in this assay, from the lowest: compound 2; then compound 1; then compounds 4 and 3 (each within the scatter of the next).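

In this assay, dimethylamino in place of piperidin-1-yl on a carbonyl carbon gives a number 8 percentage points lower from compound 3 to compound 4 (within the scatter), so the six-membered ring can go without a change that this read-out can separate from the scatter. Dimethylcarbamoyl in place of allyl on a saturated ring carbon gives a number 38 percentage points higher from compound 2 to compound 4 (beyond the scatter), and dimethylcarbamoyl in place of propyl at that same carbon gives a number 26 percentage points higher from compound 1 to compound 4 (beyond the scatter), which places compound 4 clearly apart from both chain-bearing compounds. No measurement at hand accounts for any of these steps.

The compounds shown leave open how morpholin-4-yl, pyrrolidin-1-yl or a plain amino group on that carbonyl would read, and how a carboxylic acid would read in place of the amide. They also leave open whether compound 3 and compound 4 would stay level at other doses or times.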